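This account rests on a few compounds, and the source may have more. Where it says the series, first, only, none or still open, it means among the compounds named here.

Of the compounds shown here, three have been tested, all built on the same tricyclic core that carries a chloro group and a hydrazone or hydrazide linker to a benzene ring. In a functional assay on HeLa cells (Homo sapiens) for inhibition, read by sulforhodamine B assay, with a stated time of 48 h (a lower number here means a stronger inhibitor of growth, a higher number a weaker inhibitor of growth), compound 1 `COc1cccc(/C=N\NC(=O)C2=C(Cl)c3ccccc3CCC2)c1` gives 15600 nM and compound 2 `COc1ccc(/C=N\NC(=O)C2=C(Cl)c3ccccc3CCC2)c(OC)c1` gives 38500 nM. Compound 3 `O=C(N/N=C/C1=C(Cl)c2ccccc2CCC1)c1ccccc1`, which places the benzene ring on the carbonyl side of the linker, reaches only the limit of > 100000 nM in this assay, so no number is known for it. This is the point made by the limit of > 100000 nM in this assay, at which 1 of the 3 values shown sits. Compound 4 `O=C(N/N=C/C1=C(Cl)c2ccccc2CCC1)c1cccc(Cl)c1` differs from compound 3 in a single place: chloro in place of hydrogen on an aromatic carbon. Among the measured compounds shown here, no pair of measured compounds shares this change, so the step has to be estimated without a precedent. Because compound 3 sits at > 100000 nM, the starting point itself is open-ended, and a small gain is the most that seems reasonable to expect. The step from compound 3 to compound 4 is therefore expected to be an at least 1.1-fold lower number from compound 3 to compound 4 (0.04 log units; that floor lies within the scatter). Compound 4 is estimated at 90000 nM, within a range from 25000 nM to 300000 nM.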

Compound 4, concentration for 50% growth inhibition: 19200 nM
For compound 4 the middle estimate is 4.7-fold (0.67 log units) above the measured one; the whole stated range lies above it.
By their numbers in this assay, from the lowest: compounds 1, 4 and 2 (each within the scatter of the next, the first and the last beyond it). At a limit, above all of these: compound 3.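

Putting chloro in place of hydrogen on this six-membered aromatic ring, meta to a large group, turns phenyl into 3-chlorophenyl and gives an at least 5.2-fold lower number from compound 3 to compound 4 (0.71 log units; beyond the scatter) in this assay. Among the compounds shown here, this one change is enough to give a measurable number, something the earlier compounds could not show, since no two of them differ in only one place. The true size of the step remains open-ended because compound 3 stands at a limit, not at a number: the limit of > 100000 nM in this assay, at which 1 of the 4 values shown sits.

The compounds shown cover only this one position and this one new group, so they cannot tell whether the gain is specific to chloro. Fluoro, an amine or a carboxylic acid at the same place, or chloro elsewhere on the ring, would help to settle that.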